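Amine swap carried onto the trimethylphenyl analogue

The source may report more compounds than this note shows. Statements on the series, on what has been measured and on what is new or still open speak of the compounds shown alone.

The series is followed in an assay on HEK293 cells for binding affinity to corticotropin-releasing factor receptor 1 (Homo sapiens), read by radioligand binding; a higher number here means a weaker inhibitor, a lower number a stronger inhibitor. Compound 1 `CCCCN(CC)c1nc(C)nc2c1n(C)c(=O)n2-c1ccc(C(C)C)cc1Br` gives 5 nM, and compound 2 `CCCN(CC1CC1)c1nc(C)nc2c1n(C)c(=O)n2-c1ccc(C(C)C)cc1Br` gives 5.7 nM. Compound 3 `CCCCN(CC)c1nc(C)nc2c1n(C)c(=O)n2-c1c(C)cc(C)cc1C` gives 4.4 nM, the lowest of the three numbers shown, though its gaps to compound 1 and to compound 2 both sit within the scatter, so no order among them can be read.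

Compound 4 `CCCN(CC1CC1)c1nc(C)nc2c1n(C)c(=O)n2-c1c(C)cc(C)cc1C` is the unmeasured partner of compound 3. The change is (cyclopropylmethyl)(propyl)amino in place of butyl(ethyl)amino on an aromatic carbon. For the measured compounds named here, one measured step bears on this exact change, made on the bromo-isopropylphenyl core: a 1.1-fold higher number from compound 1 to compound 2 (0.06 log units; within the scatter). That step was within the scatter, and nothing in the remaining numbers points elsewhere.

The expected result is therefore a step of no more than the scatter, in either direction, and the estimate is written as a 1.1-fold higher number from compound 3 to compound 4 (0.06 log units; within the scatter). Compound 4 is expected to give 5 nM, with a range from 2.5 nM to 10 nM.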

Compound 4, inhibition constant: 6.1 nM
The estimate for compound 4 lay 1.2-fold (0.09 log units) below the measured number, within the range that was stated.
By their numbers in this assay, from the lowest: compounds 3, 1, 2 and 4 (each within the scatter of the next).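

The swap to (cyclopropylmethyl)(propyl)amino on an aromatic carbon now has a reading on a second core, and in this assay it again stays within the scatter, with a 1.4-fold higher number from compound 3 to compound 4 (0.14 log units; within the scatter). With this amine held fixed, 2,4,6-trimethylphenyl in place of 2-bromo-4-isopropylphenyl on an aromatic nitrogen also gives no readable difference, with a 1.1-fold higher number from compound 2 to compound 4 (0.03 log units; within the scatter). The amine change therefore reads alike on both cores, with no sign so far that its result depends on the core: the same change on two cores in this assay, a 1.1-fold higher number (0.06 log units; within the scatter) from compound 1 to compound 2 and a 1.4-fold higher number (0.14 log units; within the scatter) from compound 3 to compound 4, 1.2-fold (0.08 log units) apart, within the scatter of two such steps.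

These compounds span only two closely matched amines, both fully alkyl-substituted, so they do not define how much change this position accepts. Going by these compounds, whether a morpholine, a hydroxyethyl chain or a secondary amine on this aromatic carbon would shift the number beyond the scatter remains open.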